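Acetyl for methoxy on the arylpiperazine of compound 2

A few compounds are considered here, and "the series" means these few. Any claim that something is new, unique, unknown or untested is made for them only; others in the source may bear on it.

Compound 2 `COc1cccc(N2CCN(CCCCCC(=O)NC3CCCc4ccccc43)CC2)c1` is measured in an assay on HEK293 cells for displacement of a labelled ligand from 5-hydroxytryptamine receptor 7 (Rattus norvegicus) (a higher number here means a weaker inhibitor, a lower number a stronger inhibitor), where compound 2 gives 119 nM. Compound 1 `O=C(CCCCCN1CCN(c2nc3ccccc3o2)CC1)NC1CCCc2ccccc21` gives 820 nM in this assay, so compound 2 holds the lower of the two numbers, with a 6.9-fold lower number from compound 1 to compound 2 (0.84 log units; beyond the scatter) separating them. Compound 3 `CC(=O)c1cccc(N2CCN(CCCCCC(=O)NC3CCCc4ccccc43)CC2)c1` differs from compound 2 by acetyl in place of methoxy on an aromatic carbon. Within the data shown here, the only measured step, from compound 1 to compound 2, exchanges the whole aryl group on the piperazine nitrogen and does not bear directly on swapping one substituent for another on the 3-methoxyphenyl ring; no measured pair compares methoxy with acetyl. Compound 3 is therefore expected to stay close to compound 2, with at most a small rise of a 2.1-fold higher number from compound 2 to compound 3 (0.32 log units; beyond the scatter) in this assay. Compound 3 is estimated at 250 nM, within a range from 90 nM to 700 nM.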

Compound 3, inhibition constant: 496 nM
The estimate for compound 3 lay 2.0-fold (0.30 log units) below the measured number, and the stated range covers the measured number.
By their numbers in this assay, from the lowest: compound 2; then compounds 3 and 1 (each within the scatter of the next).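

In this assay, acetyl in place of methoxy on this aromatic carbon gives a 4.2-fold higher number from compound 2 to compound 3 (0.62 log units; beyond the scatter), so the group at this place, meta to a large group, matters on its own. The earlier step exchanged the whole aryl group on the amine nitrogen in a ring, whereas this one moves the number beyond the scatter through a change of one substituent. Against 1,3-benzoxazol-2-yl, 3-acetylphenyl gives a 1.7-fold lower number from compound 1 to compound 3 (0.22 log units; within the scatter), so the separation seen with 3-methoxyphenyl does not appear with 3-acetylphenyl. Nothing available gives a reason for the methoxy-to-acetyl step.

Going by these compounds, how an ethoxy, a hydroxyl, a chlorine or an amine would read at this place remains open. So does the effect of a shorter or longer chain between the amide and the ring nitrogen.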